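Shrinking the side chain of an EZH2 inhibitor

A few compounds are considered here, and "the series" means these few. Any claim that something is new, unique, unknown or untested is made for them only; others in the source may bear on it.

Compound 1 `Cc1cc(C)c(CN2CCc3c(Cl)cc([C@@H](CO)[C@@H]4CCOC4)c(Cl)c3C2=O)c(=O)[nH]1`: 2910 nM
Compound 2 `Cc1cc(C)c(CN2CCc3c(Cl)cc([C@H](CO)[C@H]4CCOC4)c(Cl)c3C2=O)c(=O)[nH]1`: 10 nM

In an assay on cells for inhibition of histone-lysine N-methyltransferase EZH2 (Homo sapiens), read by ELISA, with a stated time of 72 h (on this read-out lower numbers stand for stronger inhibition and higher numbers for weaker inhibition), compound 2 stands lowest of the two numbers, with compound 1 at a 290-fold lower number from compound 1 to compound 2 (2.46 log units; beyond the scatter). That single step arises because of the fact that compounds 1 and 2 differ only in the configuration as drawn; it says nothing directly about swapping one group for another. Compound 3 `Cc1cc(C)c(CN2CCc3c(Cl)cc([C@H](C)CO)c(Cl)c3C2=O)c(=O)[nH]1` differs from compound 2 by a group of 4 heavy atoms (3 carbon, 1 oxygen; no ring) in place of a group of 8 heavy atoms (6 carbon, 2 oxygen; one five-membered non-aromatic ring with 1 hetero atom), on an aromatic carbon. Within the data shown here, no measured step bears on such a replacement, so the expectation rests on the change alone: the smaller group is expected to give a 6.0-fold higher number from compound 2 to compound 3 (0.78 log units; beyond the scatter). In this assay compound 3 is therefore estimated at 60 nM, within 15 nM to 250 nM.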

Compound 3, half-maximal inhibitory concentration in the histone-lysine N-methyltransferase EZH2 assay: 129 nM
Compound 3: middle estimate off by 2.2-fold (0.33 log units), on the low side; measured number inside the range.
By their numbers in the histone-lysine N-methyltransferase EZH2 assay, from the lowest: compound 2; then compound 3; then compound 1.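

In the histone-lysine N-methyltransferase EZH2 assay, the smaller 1-(hydroxymethyl)ethyl group gives a 13-fold higher number from compound 2 to compound 3 (1.11 log units; beyond the scatter), while methyl in place of oxolan-3-yl gives a 23-fold lower number from compound 1 to compound 3 (1.35 log units; beyond the scatter), so at this position the oxolan-3-yl ring can lower or raise the number, depending on the configuration as drawn. In a physicochemical assay for lipophilicity, at pH 7.4 (a higher number here means a more lipophilic compound, a lower number a more polar compound), compound 2 gives 2, and compound 3 gives 2.6.

Going by these compounds, whether an amine or a carboxylic acid in place of the hydroxyl of the 1-(hydroxymethyl)ethyl group would keep the number of compound 3 remains open. So does how the mirror image of compound 3 would compare.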